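The source may hold more compounds than are shown below. What is called first, only, known or untested is meant among the compounds shown, and "the series" means these compounds.

Compound 1 `COc1ccc(-c2cc(/C=C/C(=O)c3ccc(N)cc3)[nH]n2)cc1`, -47%; compound 2 `COc1cc(-c2cc(/C=C/C(=O)c3ccc(F)c(F)c3)[nH]n2)cc(OC)c1OC`, -20%.

In a functional assay on RXF 393 cells (Homo sapiens) for cytotoxicity, read by sulforhodamine B assay, with a stated time of 48 h, tested at 10 uM (a lower number here means a stronger effect, a higher number a weaker effect of the compound at the concentration tested), compound 1 gives -47%, the lowest of the two numbers seen so far. Compound 2 gives -20% in this assay, a number that lies beyond the scatter above that of compound 1. Compound 3 `COc1ccc(-c2cc(/C=C/C(=O)c3ccc(N)cc3)[nH]n2)cc1OC` has not yet been measured; it differs from compound 1 by methoxy in place of hydrogen on an aromatic carbon, on an aromatic carbon of a six-membered aromatic ring of carbon only, ortho to a methoxy group and meta to a large group. Going by the values given here, no measured pair shows this change on its own, so the step from compound 1 to compound 3 in this assay is expected to remain within the usual scatter, a number 7 percentage points higher from compound 1 to compound 3 (within the scatter). Compound 3 is estimated at -40%, expected between -65% and -15%.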

Compound 3, a percentage reported as activity, at one concentration (the size of the read-out at that concentration, not a potency): -39%
Estimate against measurement, compound 3: 1 percentage points below; the range from low to high includes it.
By their numbers in this assay, from the lowest: compounds 1 and 3 (each within the scatter of the next); then compound 2.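

In this assay, methoxy in place of hydrogen on an aromatic carbon, ortho to a methoxy group and meta to a large group, gives a number 8 percentage points higher from compound 1 to compound 3 (within the scatter), the first single-place step available in this series. On the core of compound 1, this position therefore accepts a methoxy group without a step beyond the scatter. No measurement bears on why this is so. On these data alone, whether a hydroxyl group or an ethoxy group on the same carbon would also give a step within the scatter remains open. So does whether the methoxy step would stay this small on another core.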